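The compounds below may be only part of what the source reports. "The series", "measured", "known", "first", "only" and "open" are said of these compounds alone.

Three compounds on the shared core differ only in the aromatic group on a saturated chain carbon bound to an amine nitrogen in a ring. In a functional assay, read by spectrophotometry, with a stated time of 30 min (on this read-out lower numbers stand for stronger inhibition and higher numbers for weaker inhibition), compound 1 (`COc1ccc(CN2CCC(CCNC(=O)/C=C/c3cc(C(C)(C)C)c(O)c(C(C)(C)C)c3)CC2)cc1`) gives 61200 nM and compound 2 (`CC(C)(C)c1cc(/C=C/C(=O)NCCC2CCN(Cc3cccc(F)c3)CC2)cc(C(C)(C)C)c1O`) gives 55200 nM while compound 3 (`CC(C)(C)c1cc(/C=C/C(=O)NCCC2CCN(Cc3ccc(F)c(F)c3)CC2)cc(C(C)(C)C)c1O`) gives 65700 nM as its result. Compound 3 therefore stands level with compound 1 and compound 2, inside the scatter of each.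

The next structure, compound 4 (`CC(C)(C)c1cc(/C=C/C(=O)NCCC2CCN(Cc3ccc(C#N)cc3)CC2)cc(C(C)(C)C)c1O`), carries 4-cyanophenyl in place of 3,4-difluorophenyl at that same place (4-cyanophenyl in place of 3,4-difluorophenyl on a saturated chain carbon bound to an amine nitrogen in a ring). The three measured steps all concern this aromatic group, so they are the ones that bear on the change. They are a 1.1-fold lower number from compound 1 to compound 2 (0.04 log units; within the scatter) and a 1.1-fold higher number from compound 1 to compound 3 (0.03 log units; within the scatter) and a 1.2-fold higher number from compound 2 to compound 3 (0.08 log units; within the scatter) and each of them is small. Among the compounds with values here, no measured compound carries a nitrile, so this group itself remains untested.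

On this evidence, no step beyond the scatter is expected in this assay and neither direction is favoured. The estimate means a 1.1-fold lower number from compound 3 to compound 4 (0.04 log units; within the scatter) as the expected step. The estimated value for compound 4 is 60000 nM with an expected range of 33000 nM to 105000 nM around it.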

Compound 4, half-maximal inhibitory concentration: 79500 nM
For compound 4 the middle estimate is 1.3-fold (0.12 log units) below the measured one; measured number inside the range.
By their numbers in this assay, from the lowest: compounds 2, 1, 3 and 4 (each within the scatter of the next).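

In this assay, within the data shown here, compound 4 is the only compound here with a nitrile, and that group leaves the result level with all three earlier compounds: the steps are a 1.2-fold higher number from compound 3 to compound 4 (0.08 log units; within the scatter) and a 1.4-fold higher number from compound 2 to compound 4 (0.16 log units; within the scatter) and a 1.3-fold higher number from compound 1 to compound 4 (0.11 log units; within the scatter) and none of them can be told apart from repeat measurement. The position on a saturated chain carbon bound to an amine nitrogen in a ring has now carried 4-methoxyphenyl, 3-fluorophenyl, 3,4-difluorophenyl and 4-cyanophenyl, and these four compounds give results that stay within the scatter of one another. Nothing measured here explains why these different groups give such similar results.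

The compounds shown all keep an aromatic ring at this place, so they cannot tell whether a cyclohexyl group in its place, a carboxylic acid or an amine on that ring, or a longer chain carrying the ring would shift the number beyond the scatter. They also leave open whether any change elsewhere on the shared core, such as to the two tert-butyl groups or the hydroxyl, would matter more than this position does.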